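A few compounds are considered here, and "the series" means these few. Any claim that something is new, unique, unknown or untested is made for them only; others in the source may bear on it.

Within the data shown here, compound 1 `N#Cc1cnc(NCc2ccccc2C(F)(F)F)cc1N[C@H]1CC[C@@H](O)CC1` gives 140 nM in an assay on isolated protein for inhibition of protein kinase C theta type (Homo sapiens), read by TR-FRET, with a stated time of 2 h (a higher number here means a weaker inhibitor, a lower number a stronger inhibitor), the lowest of the three numbers so far. Compound 2 `N#Cc1cnc(NCc2cnccc2C(F)(F)F)cc1N[C@H]1CC[C@H](O)CC1` gives 350 nM and compound 3 `CO[C@H]1CC[C@H](CNc2cc(NCc3cnccc3C(F)(F)F)ncc2C#N)CC1` gives 330 nM, both beyond the scatter above compound 1. Among the measured compounds shown here, the single measured step at the same nitrogen, a 1.1-fold lower number from compound 2 to compound 3 (0.03 log units; within the scatter), exchanges 4-hydroxycyclohexyl for (4-methoxycyclohexyl)methyl and stays within the scatter. Compound 4 `N#Cc1cnc(NCc2ccccc2C(F)(F)F)cc1N[C@H]1C[C@H](C(N)=O)C1` differs from compound 1 by 3-carbamoylcyclobutyl in place of 4-hydroxycyclohexyl on a nitrogen on an aromatic ring. For the measured compounds named here, no measured step changes the ring size at this nitrogen, so the data bear on this change only loosely; the one comparison available, from compound 2 to compound 3, suggests this nitrogen tolerates alteration. A modest rise in this assay is expected for compound 4, estimated at 350 nM with a range of 120 nM to 1000 nM, a step of a 2.5-fold higher number from compound 1 to compound 4 (0.40 log units; beyond the scatter).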

Compound 4, half-maximal inhibitory concentration: 5000 nM
For compound 4 the middle estimate is 14-fold (1.15 log units) below the measured one; measured number outside the range, above it.
By their numbers in this assay, from the lowest: compound 1; then compounds 3 and 2 (each within the scatter of the next); then compound 4.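

In this assay, a step of a 36-fold higher number from compound 1 to compound 4 (1.55 log units; beyond the scatter) shows that this nitrogen does not tolerate every alteration, in contrast to a 1.1-fold lower number from compound 2 to compound 3 (0.03 log units; within the scatter). 3-carbamoylcyclobutyl and 4-hydroxycyclohexyl have the same heavy-atom, hydrogen-bond donor and acceptor counts, so these counts alone do not track the result. No measurement here accounts for the loss.

Still open, from the compounds shown here alone, is whether the loss belongs to the four-membered ring or to the carbamoyl group, as both change together. Results for 3-hydroxycyclobutyl and 4-carbamoylcyclohexyl on this nitrogen would separate the two.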